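The compounds below may be only part of what the source reports. "The series", "measured", "known", "first", "only" and "open" are said of these compounds alone.

Measured compounds in this series:

- compound 1, `Cc1cnc(-c2nc(C(=O)N[C@@H](C)c3ccc(C(=O)NO)cc3)c(C3CC3)s2)s1`: 18.5 nM
- compound 2, `C[C@@H](NC(=O)c1nc(-c2nccs2)sc1C1CC1)c1ccc(C(=O)NO)cc1`: 211 nM
- compound 3, `CC(C)(NC(=O)c1nc(-c2nccs2)sc1C1CC1)c1ccc(C(=O)NO)cc1`: 148 nM

In an assay on cells for inhibition of protein deacetylase HDAC6 (Homo sapiens), read by fluorescence, with a stated time of 24 h (a higher number here means a weaker inhibitor, a lower number a stronger inhibitor), compound 1 gives the lowest number of the three. Compound 3 stands nearest to it, and compound 2 furthest; both gaps lie beyond the usual scatter, so compound 1 is the strongest inhibitor among the measured compounds. Among the measured compounds shown here, no single-point step between two measured compounds is available, so the effect of varying the thiazolyl substituent on the shared core of compound 1 has to be inferred from the structural change alone.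

Compound 4, `C[C@H](NC(=O)c1nc(-c2nc3c(s2)CCCC3)sc1C1CC1)c1ccc(C(=O)NO)cc1`, has not yet been measured in this assay. It differs from compound 1 in one place: a group of 9 heavy atoms (7 carbon, 1 nitrogen, 1 sulfur; one five-membered aromatic ring with 2 hetero atoms, one six-membered non-aromatic ring of carbon only) in place of a group of 6 heavy atoms (4 carbon, 1 nitrogen, 1 sulfur; one five-membered aromatic ring with 2 hetero atoms), on an aromatic carbon

The change keeps the five-membered aromatic ring with 2 hetero atoms and adds a six-membered non-aromatic ring of carbon only in place of the methyl. For the measured compounds named here, with no measured step to anchor this change, the step from compound 1 to compound 4 is expected to be small, a 1.2-fold lower number from compound 1 to compound 4 (0.06 log units; within the scatter), within or at the edge of the scatter, with no clear direction. Compound 4 is therefore estimated at 16 nM, with a range from 5 nM to 50 nM.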

Compound 4, half-maximal inhibitory concentration: 18.3 nM
For compound 4 the middle estimate is 1.1-fold (0.06 log units) below the measured one; the measured number falls inside the stated range.
By their numbers in this assay, from the lowest: compounds 4 and 1 (each within the scatter of the next); then compounds 3 and 2 (each within the scatter of the next).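

In this assay the swap of the 5-methyl-1,3-thiazol-2-yl group for the larger group with its six-membered non-aromatic ring of carbon only gives a 1.0-fold lower number from compound 1 to compound 4 (0.00 log units; within the scatter), so the two compounds cannot be told apart. Among the compounds shown here, as the only single-place step, it shows that this aromatic carbon, next to the ring nitrogen and next to the ring sulfur, can carry a group of 9 heavy atoms as well as one of 6 heavy atoms without loss in this read-out. Nothing at hand bears on the reason for this result.

Open, from the compounds shown here alone, is how far this latitude reaches: only these two groups can be compared here. An amine, a carboxylic acid or a longer chain on the thiazole ring at this place could behave quite differently.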